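A Fluorine Added to a Cytotoxicity-Inactive Benzamide

A few compounds are considered here, and "the series" means these few. Any claim that something is new, unique, unknown or untested is made for them only; others in the source may bear on it.

Compound 1 `O=C(NC/C=C\Cn1cc(C(F)(F)F)c(=O)[nH]c1=O)c1ccccc1` gives > 100000 nM in a functional assay on HEp-2 cells (Homo sapiens) for cytotoxicity, read by MTT assay, with a stated time of 72 h; a lower number here means a stronger inhibitor, a higher number a weaker inhibitor.
Compound 2 `Nc1ccn(C/C=C\CNC(=O)c2ccccc2)c(=O)n1` gives > 100000 nM in this assay.

Both of these values are limits of the assay, not measured numbers. Going by these compounds, compound 2 stands at the limit of > 100000 nM in this assay, at which 2 of the 2 values shown sit, so its true potency is unknown beyond being weak. Compound 3 `Nc1ccn(C/C=C\CNC(=O)c2ccc(F)cc2)c(=O)n1` differs from compound 2 by fluoro in place of hydrogen on an aromatic carbon. Within the data shown here, no step between measured compounds is available to size such a change. The step from compound 2 to compound 3 is expected to be a step that the limit leaves unreadable from compound 2 to compound 3, none beyond the usual scatter in this assay. Compound 3 is estimated at 150000 nM, within 50000 nM to 500000 nM, and most likely again reported only as a limit.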

Compound 3, half-maximal inhibitory concentration: > 100000 nM
Compound 3: a limit, no number (the forecaster's own chance of this, stated with the estimate: 85%); the middle value lies beyond the limit too.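

Compound 2 and compound 3 both give only a limit, not a number, and the step between them cannot be read. Still open, going by these compounds, is how strongly compound 1, compound 2 and compound 3 truly act in this assay.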